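A Methoxy Group Added to the Anilide of Compound 1

This account rests on a few compounds, and the source may have more. Where it says the series, first, only, none or still open, it means among the compounds named here.

compound 1 `COc1ccc2c(=O)c(/C=C/C(=O)Nc3ccccc3)coc2c1`: 9050 nM
compound 2 `COc1ccc(NC(=O)/C=C/c2coc3cc(O)ccc3c2=O)cc1`: > 100000 nM

For the measured compounds named here, in a functional assay on Huh-7 cells (Homo sapiens) for inhibition, read by MTT assay, with a stated time of 48 h (on this read-out lower numbers stand for stronger inhibition and higher numbers for weaker inhibition), compound 1 gives 9050 nM, the only numerical value recorded in this set. Compound 2 is reported only as a limit, namely (the limit of > 100000 nM in this assay, at which 1 of the 2 values shown sits), and not as a number. Compound 3 `COc1ccc2c(=O)c(/C=C/C(=O)Nc3ccccc3OC)coc2c1` is not yet measured; it differs from compound 1 by methoxy in place of hydrogen on an aromatic carbon. Going by the values given here, with no measured step of this kind to lean on, the expected change in this assay is small, at most a modest weakening and quite possibly nothing beyond the scatter. Compound 3 is accordingly estimated at 12000 nM, between 3500 nM and 45000 nM, an expected step of a 1.3-fold higher number from compound 1 to compound 3 (0.12 log units; within the scatter).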

Compound 3, half-maximal inhibitory concentration: 32300 nM
Compound 3: middle estimate off by 2.7-fold (0.43 log units), on the low side; the range from low to high includes it.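

Methoxy in place of hydrogen, ortho to a large group, now has a measured step in this assay: a 3.6-fold higher number from compound 1 to compound 3 (0.55 log units; beyond the scatter). This single step shows that this position responds to the change, with inhibition weakening beyond the scatter rather than holding steady. Nothing shown here gives a cause for that loss.

As far as these compounds go, whether the loss belongs to methoxy itself or to any group at this place stays open, as does the response to fluorine, an amine or a carboxylic acid here. How methoxy acts at other carbons of this ring is also unresolved.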